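The source may hold more compounds than are shown below. What is called first, only, known or untested is meant among the compounds shown, and "the series" means these compounds.

Measured in a functional assay on PC-3 cells (Homo sapiens) for antiproliferative activity, read by MTT assay, with a stated time of 24 h; on this read-out lower numbers stand for stronger inhibition and higher numbers for weaker inhibition:
Compound 1 `CCn1c(C(=O)N[C@@H](CC(=O)OC)C(=O)OC)ccc1C(CC)(CC)c1ccc(OCS(=O)(=O)c2ccccc2)c(C)c1`: 6490 nM
Compound 2 `CCn1c(C(=O)N[C@H](CO)CCCO)ccc1C(CC)(CC)c1ccc(OCS(=O)(=O)c2ccccc2)c(C)c1`: 6810 nM

On these numbers, compound 2 stands level with compound 1, within the usual scatter of repeated measurements. Compound 3 `CCn1c(C(=O)N[C@@H](C)C(=O)O)ccc1C(CC)(CC)c1ccc(OCS(=O)(=O)c2ccccc2)c(C)c1` differs from compound 2 on the amide-type nitrogen: a group of 5 heavy atoms (3 carbon, 2 oxygen; no ring) in place of a group of 7 heavy atoms (5 carbon, 2 oxygen; no ring), on an amide-type nitrogen. Within the data shown here, the only measured step, a 1.0-fold higher number from compound 1 to compound 2 (0.02 log units; within the scatter), also exchanged one group without a ring for another at that nitrogen, and it stayed within the scatter. No step beyond the scatter is therefore expected in this assay, though one step is thin evidence. The expected change is a 1.0-fold higher number from compound 2 to compound 3 (0.01 log units; within the scatter). The estimate for compound 3 is 7000 nM, with an expected range of 3000 nM to 16000 nM.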

Compound 3, half-maximal inhibitory concentration: 16800 nM
Estimate against measurement, compound 3: 2.4-fold (0.38 log units) below, outside the stated range (above it).
By their numbers in this assay, from the lowest: compounds 1 and 2 (each within the scatter of the next); then compound 3.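

In this assay the group on the amide-type nitrogen turns out to matter: with 1-carboxyethyl there, the measurement shows a 2.5-fold higher number from compound 2 to compound 3 (0.39 log units; beyond the scatter) and also a 2.6-fold higher number from compound 1 to compound 3 (0.41 log units; beyond the scatter) as modest steps toward weaker inhibition. The earlier exchange at this nitrogen stayed within the scatter, so this position does not accept every group equally. No measured evidence bears on the reason for this. The compounds shown leave open whether an amine, or a longer chain ending in a carboxylic acid, on this nitrogen would restore inhibition or weaken it further.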